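The compounds below may be only part of what the source reports. "The series", "measured", "known", "first", "only" and "open" are said of these compounds alone.

Compound 1 `CCCCc1cnc(C(CCCO)Cc2ccc(-c3ccccc3C(=O)O)cc2)[nH]1` gives 1900 nM in an in vitro functional assay on cells for agonist activity at Bombesin receptor subtype-3 (Homo sapiens), read by luminescence and calcium flux; on this read-out higher numbers stand for an effect only at larger amounts of compound and lower numbers for an effect already at smaller amounts.
Compound 2 `CCCCc1cnc(CCc2ccc(-c3ccccc3C(=O)O)cc2)[nH]1` gives 2710 nM in this assay.
Compound 3 `O=C(O)c1ccccc1-c1ccc(CCc2ncc(CC3CCCCC3)[nH]2)cc1` gives 41 nM in this assay.

Compound 3 stands lowest of the three, set apart from compound 1 and compound 2 by steps beyond the scatter. Compound 4 `Cc1ccc(Cc2cnc(CCc3ccc(-c4ccccc4C(=O)O)cc3)[nH]2)cc1` differs from compound 3 by 4-methylphenyl in place of cyclohexyl on a saturated chain carbon bound to an aromatic carbon. Among the measured compounds shown here, the one measured step at this place is a 66-fold lower number from compound 2 to compound 3 (1.82 log units; beyond the scatter), which shows how strongly this position responds to a larger group; the step of a 1.4-fold higher number from compound 1 to compound 2 (0.15 log units; within the scatter) lies elsewhere and says little here. For the measured compounds named here, no measured pair compares a saturated ring with an aromatic ring at this place, so only a modest shift is expected, with a 2.0-fold higher number from compound 3 to compound 4 (0.29 log units; within the scatter) taken as the estimated step. Compound 4 is therefore expected to give about 80 nM, with a range from 25 nM to 300 nM.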

Compound 4, half-maximal effective concentration: 2660 nM
The estimate for compound 4 lay 33-fold (1.52 log units) below the measured number; the whole stated range lies below it.
By their numbers in this assay, from the lowest: compound 3; then compounds 1, 4 and 2 (each within the scatter of the next).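

Putting 4-methylphenyl in place of cyclohexyl at this place gives a 65-fold higher number from compound 3 to compound 4 (1.81 log units; beyond the scatter) and so undoes the earlier drop, while 4-methylphenyl in place of propyl gives a 1.0-fold lower number from compound 2 to compound 4 (0.01 log units; within the scatter) and leaves no difference that can be told apart. A larger group at this place is therefore not enough: among these compounds, only the non-aromatic cyclohexyl ring goes with the low number. Nothing available explains why the two rings differ so much. On these data alone, whether the methyl or the aromatic ring itself matters stays open; phenyl, cyclopentyl or piperidinyl at this place would help separate these.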